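The compounds below may be only part of what the source reports. "The series", "measured", "known", "first", "only" and "open" are said of these compounds alone.

Compound 1, `COc1cc(-n2ncnc2-c2ccccc2)cc(OC)c1OC`, gives > 10000 nM in a functional assay on HeLa cells (Homo sapiens) for antiproliferative activity, read by MTT assay, with a stated time of 72 h (a higher number here means a weaker inhibitor, a lower number a stronger inhibitor), which is a limit of the assay and not a number.
Compound 2, `CCOc1ccccc1-c1ncnn1-c1cc(OC)c(OC)c(OC)c1`, gives > 10000 nM in this assay, again a limit and not a number.
Compound 3, `CCOc1ccc(-c2ncnn2-c2cc(OC)c(OC)c(OC)c2)cc1`, gives 15 nM in this assay.

Going by these compounds, compound 1 thus stands at the limit of > 10000 nM in this assay, at which 2 of the 3 values shown sit, so its exact value is unknown. From compound 1 the step to compound 2 reads a step that the two limits leave unreadable from compound 1 to compound 2, while the step to compound 3 reads an at least 660-fold lower number from compound 1 to compound 3 (2.82 log units; beyond the scatter). Compound 4, `COc1cccc(-c2ncnn2-c2cc(OC)c(OC)c(OC)c2)c1`, differs from compound 1 by methoxy in place of hydrogen on an aromatic carbon. Neither measured step matches this change exactly: both add an ethoxy group rather than a methoxy, and at different positions of the same ring, with one step unreadable and the other large. He therefore expects a drop in this assay for compound 4 below the limit seen for compound 1, though not necessarily as deep as that of compound 3, with wide uncertainty. His estimate for compound 4 is 1500 nM, between 100 nM and 10000 nM, a step of an at least 6.6-fold lower number from compound 1 to compound 4 (0.82 log units; beyond the scatter).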

Compound 4, half-maximal inhibitory concentration: > 10000 nM
Compound 4 gave a limit, no number; the forecaster's own chance of this, stated with the estimate: 35%; middle value at least 6.6-fold (0.82 log units) from the limit.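

Compound 1 and compound 4 both rest at a limit and not at a number, so the step between them cannot be read: the limit of > 10000 nM in this assay, at which 3 of the 4 values shown sit. The compounds shown leave open whether methoxy in place of hydrogen on an aromatic carbon changes the activity of compound 1 at all.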